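A few compounds are considered here, and "the series" means these few. Any claim that something is new, unique, unknown or untested is made for them only; others in the source may bear on it.

Compound 3 `O=C(/C=C/c1cn([C@H]2C[C@H](CO)N(CCCc3ccccc3)C2)nn1)NO` was tested in an assay on Sf9 cells for inhibition of histone deacetylase 11 (Homo sapiens), read by fluorescence, tested at 0.5 uM (a lower number here means less inhibition, a higher number more inhibition at the concentration tested (going by the name of the read-out)), where compound 3 gives 16%. On the three numbers shown it stands second highest, though all lie close together: compound 2 `O=C(NO)c1ccc(-c2cn([C@H]3C[C@H](CO)N(CCCc4ccccc4)C3)nn2)cc1` gives 18% and compound 1 `O=C(/C=C/c1cn([C@@H]2C[C@H](CO)N(CCCc3ccccc3)C2)nn1)NO` gives 12%. The step of a number 4 percentage points higher from compound 1 to compound 3 (within the scatter) concerns only the drawn configuration, as shown by the fact that compounds 1 and 3 differ only in the configuration as drawn, and the step of a number 2 percentage points lower from compound 2 to compound 3 (within the scatter) exchanges the group on an aromatic carbon. Compound 4 `O=C(/C=C/c1cn([C@H]2C[C@H](C(=O)O)N(CCCc3ccccc3)C2)nn1)NO` differs from compound 3 by carboxy in place of hydroxymethyl on a saturated ring carbon. Going by the values given here, neither measured step touches this saturated ring carbon, so no step bears directly on the change, and no movement beyond the scatter is expected: a number 1 percentage points lower from compound 3 to compound 4 (within the scatter). Compound 4 is therefore estimated at 15%, within 4% to 30%.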

Compound 4, a percentage reported as inhibition, at one concentration (the size of the read-out at that concentration, not a potency): 20%
Estimate against measurement, compound 4: 5 percentage points below; low and high end bracket the measured number.
By their numbers in this assay, from the lowest: compounds 1, 3, 2 and 4 (each within the scatter of the next).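

At this saturated ring carbon, carboxy in place of hydroxymethyl gives a number 4 percentage points higher from compound 3 to compound 4 (within the scatter) in this assay. This is the first change shown at this position, and at the single concentration tested, exchanging these two groups does not move the number beyond the scatter. Nothing available bears on why the step has this size.

As far as these compounds go, whether an amine, a methyl ester or a longer chain on this carbon would move the number beyond the scatter remains open. From the compounds shown here alone, whether carboxy would behave the same way on the core of compound 2 also remains open.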